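A few compounds are considered here, and "the series" means these few. Any claim that something is new, unique, unknown or untested is made for them only; others in the source may bear on it.

Compound 1 `CCCCCCCCc1cn([C@H]2C[C@@H]3OP(=O)(O)OC[C@H]3O2)c(=O)[nH]c1=O` and compound 3 `CCCCCCc1cn([C@H]2C[C@@H]3OP(=O)(O)OC[C@H]3O2)c(=O)[nH]c1=O` share one core; in a functional assay on Raji cells (Homo sapiens) (on this read-out higher numbers stand for weaker inhibition and lower numbers for stronger inhibition), compound 1 gives 165 ug/mL. For compound 3 this assay reports only a limit, > 500 ug/mL. The two differ by hydrogen in place of ethyl on a saturated chain carbon, six bonds along the chain from an aromatic carbon, and that change gave an at least 3.0-fold higher number from compound 1 to compound 3 (0.48 log units; beyond the scatter), a step that ends at a limit, (the limit of > 500 ug/mL in this assay, at which 1 of the 3 values shown sits). Compound 2 `CCCCCCc1cn([C@H]2C[C@H](O)[C@@H](CO)O2)c(=O)[nH]c1=O` gives 151 ug/mL in this assay; how its core differs from that of compound 1 is not broken down here. Compound 4 `CCCCc1cn([C@H]2C[C@H](O)[C@@H](CO)O2)c(=O)[nH]c1=O` differs from compound 2 by hydrogen in place of ethyl on a saturated chain carbon, four bonds along the chain from an aromatic carbon, the same kind of change, placed four bonds rather than six bonds along the chain from an aromatic carbon. Since shortening the chain gave an at least 3.0-fold higher number from compound 1 to compound 3 (0.48 log units; beyond the scatter), a weakening of about that size is expected from compound 2 to compound 4, a 3.0-fold higher number from compound 2 to compound 4 (0.47 log units; beyond the scatter). Compound 4 is therefore estimated at 450 ug/mL, expected to lie between 200 ug/mL and 1000 ug/mL.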

Compound 4, concentration for 50% inhibition: > 500 ug/mL
Compound 4 gave a limit, no number (the forecaster's own chance of this, stated with the estimate: 45%); middle value at least 1.1-fold (0.04 log units) away from the limit.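

In this assay, shortening the chain on the second core gave an at least 3.3-fold higher number from compound 2 to compound 4 (0.51 log units; beyond the scatter), which points the same way as the step seen on the first core. The value of compound 4, > 500 ug/mL, is a limit and not a number. The weakening therefore carries over from one core to the other in direction, but its size cannot be compared: the same change on two cores in this assay, an at least 3.0-fold higher number (0.48 log units; beyond the scatter) from compound 1 to compound 3 and an at least 3.3-fold higher number (0.51 log units; beyond the scatter) from compound 2 to compound 4; the limit leaves it open whether they differ

The compounds shown leave open how a longer chain would behave on either core. As far as these compounds go, it is also open whether a chain carrying an amine or a carboxylic acid would follow the same trend.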